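The source may hold more compounds than are shown below. What is called first, only, known or untested is meant among the compounds shown, and "the series" means these compounds.

Measured in an ADME assay on a cell-free system (plasma, Rattus norvegicus) for metabolic stability, read by LC-MS, with a stated time of 1 h, at 37 degrees C, tested at 100 uM; on this read-out higher numbers stand for a more stable compound and lower numbers for a less stable compound:

Compound 1 `O=C1c2ccc(OCc3cccc(-c4ccc(Cl)cc4F)c3)cc2CN1C1CCCC1`: "not determined" (no result reported)
Compound 2 `CN(C)C(=O)c1cc(-c2cccc(COc3ccc4c(=O)n(C5CCCC5)sc4c3)c2)ccc1Cl`: 100%
Compound 3 `O=C(O)c1cc(-c2cccc(COc3ccc4c(c3)CN(C3CCCC3)C4=O)c2)ccc1O`: 98%

Only two of these compounds have a number. In this assay, compound 3 reads 98% and compound 2 reads 100%, and these two values lie within the scatter of each other. Compound 1 adds nothing to the comparison, as no result was reported for it.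

The next compound to be tested is compound 4 `COc1ccc(-c2cccc(COc3ccc4c(c3)CN(C3CCCC3)C4=O)c2)cc1C(=O)O`. Its structure departs from that of compound 3 at a single place: methyl in place of hydrogen on an oxygen on an aromatic ring. This puts methyl in place of hydrogen on an oxygen on an aromatic ring, so that hydroxy becomes methoxy and 3-carboxy-4-hydroxyphenyl becomes 3-carboxy-4-methoxyphenyl.

Going by the values given here, no pair of measured compounds differs in one place, so the data hold no direct precedent for this change. The expectation therefore rests on the starting value, with compound 3 at 98% showing nearly all of the compound remaining after the incubation. No step beyond the scatter is expected, and the estimate is a number 1 percentage points lower from compound 3 to compound 4 (within the scatter). For compound 4 the expected value is 97%, with an estimated range from 87% to 100%.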

Compound 4, percent of the compound remaining: 100%
Estimate against measurement, compound 4: 3 percentage points below; measured number inside the range.
By their numbers in this assay, from the lowest: compounds 3, 2 and 4 (each within the scatter of the next).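

Going by these compounds alone, compound 3 and compound 4 form the first pair in this assay that differs in one place, and placing methyl on the hydrogen's oxygen on the aromatic ring gives a number 2 percentage points higher from compound 3 to compound 4 (within the scatter) on this read-out. At this position, therefore, hydroxy and methoxy cannot be told apart here, and the 3-carboxy-4-methoxyphenyl group reads alike with the 3-carboxy-4-hydroxyphenyl group, with the carboxylic acid kept in both compounds. Nothing among the data shown explains why the two compounds read alike, and no cause can be given for it.

From the compounds shown here alone, both values lie at the top of the scale, so it remains open whether a longer chain on this oxygen, such as ethoxy, or an amine in place of the methoxy group would also leave the reading within the scatter. It is equally open how a methyl ester in place of the carboxylic acid would read with either hydroxy or methoxy at this position, as no pair shown tests a change at that group.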